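A few compounds are considered here, and "the series" means these few. Any claim that something is new, unique, unknown or untested is made for them only; others in the source may bear on it.

Working notes on the cytotoxicity of this series. Compound 1 `O=C(CSc1snnc1-c1ccc(Br)cc1Br)Nc1ccccc1Cl` is tested in an ADME assay on MT4 cells (Homo sapiens) for cytotoxicity, read by MTT assay, with a stated time of 5 days; a higher number here means that more compound is tolerated, a lower number that less compound is tolerated. In this assay compound 1 reaches only the limit of the test, > 240000 nM, and no number is reported. Compound 2 `CC(=O)c1ccc(NC(=O)CSc2snnc2-c2ccc(Br)cc2Br)c(Br)c1` likewise shows only a limit in this assay, > 206000 nM. So compound 1 stands at the upper end of what the measurement can tell: both values shown are limits, one at the limit of > 240000 nM in this assay, at which 1 of the 2 values shown sits, and one at the limit of > 206000 nM in this assay, at which 1 of the 2 values shown sits, and neither compound 1 nor compound 2 shows cytotoxicity within the tested range.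

Compound 3 `Cc1ccc(NC(=O)CSc2snnc2-c2ccc(Br)cc2Br)cc1` differs from compound 1 by 4-methylphenyl in place of 2-chlorophenyl on an amide-type nitrogen. Going by the values given here, no measured step between compounds is available in this assay. With compound 1 and compound 2 both sitting at limits, the expectation for the step from compound 1 to compound 3 is no change beyond the scatter, a step that the limit leaves unreadable from compound 1 to compound 3. Compound 3 is therefore estimated at 250000 nM in this assay, in a range from 100000 nM to 600000 nM, most likely again reported only as a limit.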

Compound 3, half-maximal cytotoxic concentration: 24000 nM
Beside the measured number, compound 3's estimate is 10-fold (1.02 log units) above it; measured number below the stated range.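

In this assay, 4-methylphenyl in place of 2-chlorophenyl on the amide-type nitrogen gives an at least 10-fold lower number from compound 1 to compound 3 (1.00 log units; beyond the scatter), so this position can bring cytotoxicity into the tested range, which the earlier limits could not show. The two groups differ both in the substituent and in its numbered place on the phenyl ring, and this single step does not separate those two changes. The true size of the step stays unknown because compound 1 carries only a limit: the limit of > 240000 nM in this assay, at which 1 of the 3 values shown sits.

Going by these compounds, it remains open whether the methyl group, the loss of chlorine or the change of numbered place accounts for the lower tolerated concentration. 4-Chlorophenyl and 2-methylphenyl on the same nitrogen would separate these readings, and an aminophenyl group would show whether a non-carbon substituent at this position is tolerated differently.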